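From amino acid amide to fluorobenzyl ester

The source may report more compounds than this note shows. Statements on the series, on what has been measured and on what is new or still open speak of the compounds shown alone.

- compound 1 `CCn1c(C(=O)NCCN(C)C)ccc1C(CC)(CC)c1ccc(OCC(O)C(C)(C)C)c(C)c1`: 870 nM
- compound 2 `C#CCNC(=O)c1ccc(C(CC)(CC)c2ccc(OCC(O)C(C)(C)C)c(C)c2)n1CC`: > 50000 nM (a limit)
- compound 3 `CC[C@@H](C)[C@H](NC(=O)c1ccc(C(CC)(CC)c2ccc(OCC(O)C(C)(C)C)c(C)c2)n1CC)C(=O)O`: 127 nM

Among the measured compounds shown here, in a functional assay on HepG2 cells (Homo sapiens), read by MTT assay, with a stated time of 48 h (a higher number here means a weaker inhibitor, a lower number a stronger inhibitor), compound 3 gives 127 nM, the lowest number measured so far. Its nearest neighbour shows a 6.9-fold lower number from compound 1 to compound 3 (0.84 log units; beyond the scatter). Compound 2 has only a limit, > 50000 nM.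

Compound 4 `CCn1c(C(=O)OCc2ccc(F)cc2)ccc1C(CC)(CC)c1ccc(OCC(O)C(C)(C)C)c(C)c1` has (4-fluorobenzyl)oxy in place of (1-carboxy-2-methylbutyl)amino on a carbonyl carbon. For the measured compounds named here, no measured compound carries (4-fluorobenzyl)oxy, so the only guides are the measured swaps of the group on the amide-type nitrogen. Both compounds lacking the 1-carboxy-2-methylbutyl group stand higher, as a 6.9-fold lower number from compound 1 to compound 3 (0.84 log units; beyond the scatter) and an at least 390-fold lower number from compound 2 to compound 3 (2.59 log units; beyond the scatter) show. These steps differ widely in size, and an at least 57-fold higher number from compound 1 to compound 2 (1.75 log units; beyond the scatter) shows how far two such groups can lie apart. A clearly higher number in this assay is therefore expected, of modest to large size. The expected step is a 24-fold higher number from compound 3 to compound 4 (1.37 log units; beyond the scatter). Compound 4 is estimated at 3000 nM, with an expected range from 250 nM to 40000 nM.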

Compound 4, half-maximal inhibitory concentration: > 50000 nM
Compound 4 gave a limit, no number (the forecaster's own chance of this, stated with the estimate: 20%); middle value at least 16-fold (1.22 log units) from the limit.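

In this assay, among the compounds shown here, the earlier compounds varied only the group on the amide-type nitrogen, whereas compound 4 changes the link itself, with (4-fluorobenzyl)oxy on the carbonyl carbon giving an ester and removing the amide hydrogen. This costs much of the activity, with an at least 390-fold higher number from compound 3 to compound 4 (2.59 log units; beyond the scatter) and an at least 57-fold higher number from compound 1 to compound 4 (1.75 log units; beyond the scatter). Compound 4 has only a limit, so the step from compound 2 to compound 4 cannot be read, and an amide link alone does not secure a measurable number, as compound 2 also stands at that same limit: the limit of > 50000 nM in this assay, at which 2 of the 4 values shown sit.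

The oxygen link and the fluorinated benzyl group enter together, so the compounds shown leave open which of them accounts for the rise. On these data alone, a 4-fluorobenzyl amide would separate the two, and a free carboxylic acid on this carbonyl carbon remains open as well.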